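The compounds below may be only part of what the source reports. "The series", "measured", "known", "first", "only" and "open" are said of these compounds alone.

Working notes on the series. Compound 1 `COc1cc2ncnc(Nc3cccc(Br)c3)c2cc1OCCCCC(=O)Nc1ccc(S(N)(=O)=O)cc1` carries 3-bromophenyl on a nitrogen on an aromatic ring of the shared core; in a functional assay on A549 cells (Homo sapiens) for antiproliferative activity, read by MTT assay, with a stated time of 72 h (on this read-out lower numbers stand for stronger inhibition and higher numbers for weaker inhibition), compound 1 gives 14900 nM. Compound 2 `COc1cc2ncnc(Nc3ccc(Cl)cc3)c2cc1OCCCCC(=O)Nc1ccc(S(N)(=O)=O)cc1` has 4-chlorophenyl at that position. In this assay compound 2 reaches only the assay limit, > 40000 nM, not a number. Compound 3 `COc1cc2ncnc(Nc3ccc(C(F)(F)F)cc3)c2cc1OCCCCC(=O)Nc1ccc(S(N)(=O)=O)cc1` carries 4-(trifluoromethyl)phenyl, and in this assay compound 3 gives 14800 nM, the lowest of the two numbers shown; compound 1 is nearest, and a 1.0-fold lower number from compound 1 to compound 3 (0.00 log units; within the scatter), so the two cannot be told apart. Against compound 2 the gap is larger: an at least 2.7-fold lower number from compound 2 to compound 3 (0.43 log units; beyond the scatter), and likewise an at least 2.6-fold higher number from compound 1 to compound 2 (0.42 log units; beyond the scatter), both framed by the limit of > 40000 nM in this assay, at which 1 of the 3 values shown sits.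

Compound 4 `COc1cc2ncnc(Nc3ccc(C)cc3)c2cc1OCCCCC(=O)Nc1ccc(S(N)(=O)=O)cc1` is not yet measured; it differs from compound 3 by methyl in place of trifluoromethyl on an aromatic carbon. Among the measured compounds shown here, the one measured step at the same place, an at least 2.7-fold lower number from compound 2 to compound 3 (0.43 log units; beyond the scatter), shows that exchanging the group para to a large group can move the number by a modest amount. Nothing measured fixes the direction for methyl. Compound 2 shows only a limit, > 40000 nM, which tilts the expectation for the smaller group toward a higher number. Compound 4 is therefore expected to give 22000 nM in this assay, within 8000 nM to 60000 nM, corresponding to a 1.5-fold higher number from compound 3 to compound 4 (0.17 log units; within the scatter).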

Compound 4, half-maximal inhibitory concentration: > 40000 nM
Compound 4 was reported as a limit; the forecaster's own chance of this, stated with the estimate: 30%; at least 1.8-fold (0.25 log units) between middle value and limit.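

In this assay, methyl in place of trifluoromethyl gives an at least 2.7-fold higher number from compound 3 to compound 4 (0.43 log units; beyond the scatter) and so shows that the number at this place, para to a large group, depends on which small group sits there, a second readable step beside the one from chloro. Of the three groups shown at this place, only trifluoromethyl gives a number, and 4-methylphenyl in place of 3-bromophenyl gives an at least 2.6-fold higher number from compound 1 to compound 4 (0.42 log units; beyond the scatter) as well. Compound 4 stands at a limit and not at a number, compound 2 does too, so the step between them cannot be read, and the limit now holds both: the limit of > 40000 nM in this assay, at which 2 of the 4 values shown sit.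

Chloro and methyl therefore cannot be ordered against each other. From the compounds shown here alone, whether an amine, a carboxylic acid or a methoxy at this place would give a number in this assay stays open.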